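Acetylation of the remaining hydroxy group in a lactone series

A few compounds are considered here, and "the series" means these few. Any claim that something is new, unique, unknown or untested is made for them only; others in the source may bear on it.

Compound 3 `CCCC[C@@H](/C=C\[C@@H]1OC(=O)C=C[C@@H]1O)OC(C)=O` gives 0.8 ug/mL in a functional assay on LNCaP cells (Homo sapiens) for cytotoxicity, read by sulforhodamine B assay, with a stated time of 72 h; on this read-out lower numbers stand for an effect already at smaller amounts and higher numbers for an effect only at larger amounts of compound. That is the lowest of the three numbers recorded, but compound 2 `CCCC[C@H](O)/C=C\[C@@H]1OC(=O)C=C[C@@H]1OC(C)=O`, which gives 0.9 ug/mL in this assay, sits within the scatter of it, so the two cannot be ranked. Compound 1 `CC(=O)O[C@@H](C)[C@@H](/C=C/[C@@H]1O[C@@H]1[C@H]1CC=CC(=O)O1)OC(C)=O`, built on a different core and carrying two acetyl groups, gives 1.8 ug/mL in this assay, a number beyond the scatter above compound 3.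

Compound 4 `CCCC[C@@H](/C=C\[C@@H]1OC(=O)C=C[C@@H]1OC(C)=O)OC(C)=O` has not yet been measured. It differs from compound 3 by acetyl in place of hydrogen on an oxygen on a saturated carbon, so the change reads hydroxy to acetoxy. For the measured compounds named here, no measured pair shows this change on the shared core. Compounds 2 and 3, each with one acetyl group, lie within the scatter of one another, and compound 1 with two acetyl groups lies higher; a step towards a higher number is expected in this assay, but one that stays within the scatter.

Compound 4 is therefore expected to give 1.2 ug/mL in this assay, with a range of 0.5 ug/mL to 3 ug/mL. The expected step of a 1.5-fold higher number from compound 3 to compound 4 (0.18 log units; within the scatter) is within the scatter.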

Compound 4, concentration for half-maximal effect: 0.7 ug/mL
For compound 4 the middle estimate is 1.7-fold (0.23 log units) above the measured one; low and high end bracket the measured number.
By their numbers in this assay, from the lowest: compounds 4, 3, 2 and 1 (each within the scatter of the next, the first and the last beyond it).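

In this assay acetyl in place of hydrogen on an oxygen on a saturated carbon gives a 1.1-fold lower number from compound 3 to compound 4 (0.06 log units; within the scatter) and, read from the other oxygen, a 1.3-fold lower number from compound 2 to compound 4 (0.11 log units; within the scatter) and both steps lie within the scatter. On the shared core, then, a free hydroxy group is not required for a number of this size, since compound 4 carries acetoxy on both oxygens and has no hydroxy group left. Nothing available explains why this change leaves the number within the scatter.

On these data alone, whether a longer acyl chain or a benzoyl group on these oxygens would stay within the scatter remains open, as does the number for the shared core with hydroxy on both oxygens. The core of compound 1 has no partner differing in one place, so the same change cannot be judged there.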